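The source may report more compounds than this note shows. Statements on the series, on what has been measured and on what is new or still open speak of the compounds shown alone.

The study concerns a series built on the core of compound 1, `CCOC(=O)c1cc(-c2cccc(OCc3cccc(F)c3)c2)on1`. Compound 1 stands only at a limit, not at a number: in an ADME assay on Vero cells (Chlorocebus sabaeus) for cytotoxicity, with a stated time of 72 h (a higher number here means a weaker inhibitor, a lower number a stronger inhibitor), compound 1 gives > 128000 nM, which is a limit of the assay. Compound 2, `CCOC(=O)c1cc(-c2cccc(OCc3ccccc3Cl)c2)on1`, likewise stands at a limit in this assay, giving > 128000 nM. Compound 3, `CCOC(=O)c1cc(-c2cccc(OCc3ccc(Cl)c(Cl)c3)c2)on1`, has no result in this assay, recorded as "not determined" (no result reported). Among the measured compounds shown here, the single step between measured compounds differing in one place, a step that the two limits leave unreadable from compound 1 to compound 2, is left unreadable by the two limits. Compound 4, `CCOC(=O)c1cc(-c2cccc(OCc3cc(F)ccc3F)c2)on1`, differs from compound 1 by fluoro in place of hydrogen on an aromatic carbon. For the measured compounds named here, no measured step bears readably on this change; what the series shows is the limit of > 128000 nM in this assay, at which 2 of the 3 values shown sit, where compound 1 and compound 2 both sit. The account therefore expects no step beyond the scatter in this assay, and expects compound 4 to stand at the same limit, the estimated step being a step that the limit leaves unreadable from compound 1 to compound 4. The estimate for compound 4 in this assay is 160000 nM, within a range from 60000 nM to 500000 nM.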

Compound 4, half-maximal inhibitory concentration: > 128000 nM
Compound 4: no number, only a limit (the forecaster's own chance of this, stated with the estimate: 85%); the middle value is on the limit's open side.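

Compound 4, like compound 1 and compound 2, gives only a limit, so no step among these compounds can be read: the limit of > 128000 nM in this assay, at which 3 of the 4 values shown sit. The compounds shown leave open whether any change to the core of compound 1 would give a readable number in this assay.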